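The source may report more compounds than this note shows. Statements on the series, on what has been measured and on what is new or still open speak of the compounds shown alone.

Compound 3 (`CCCCc1oc2ccccc2c1C(=O)c1ccc(OCCCC(=O)N(C)Cc2ccccc2)cc1`) gives > 50000 nM in a functional assay on MCF7 cells (Homo sapiens) for antiproliferative activity, read by MTT assay, with a stated time of 24 h (on this read-out lower numbers stand for stronger inhibition and higher numbers for weaker inhibition), which is a limit of the assay and not a number. Compound 1 (`CCCCNC(=O)CCCOc1ccc(C(=O)c2c(CCCC)oc3ccccc23)cc1`), which keeps the amide hydrogen, gives > 50000 nM, also a limit. Compound 2 (`CCCCc1oc2ccccc2c1C(=O)c1ccc(OCCCC(=O)N2CCOCC2)cc1`) gives 41200 nM. The picture so far is mostly (the limit of > 50000 nM in this assay, at which 2 of the 3 values shown sit).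

Compound 4 (`CCCCc1oc2ccccc2c1C(=O)c1ccc(OCCCC(=O)N[C@@H](C)c2ccccc2)cc1`) differs from compound 3 by (1-phenylethyl)amino in place of benzyl(methyl)amino on a carbonyl carbon, with (1-phenylethyl)amino in place of benzyl(methyl)amino on a carbonyl carbon. Among the measured compounds shown here, the steps that bear on this change are those at the same carbonyl carbon: an at least 1.2-fold lower number from compound 1 to compound 2 (0.08 log units; that floor lies within the scatter), an at least 1.2-fold higher number from compound 2 to compound 3 (0.08 log units; that floor lies within the scatter) and a step that the two limits leave unreadable from compound 1 to compound 3. None of them is shown to go beyond the scatter, so no step beyond the scatter is expected in this assay, and the direction stays open. The estimated step is a number no higher from compound 3 to compound 4 (the limit leaves the size open). A report of only a limit is more likely than not for compound 4. The expected value for compound 4 is 50000 nM, with an estimated range from 25000 nM to 100000 nM.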

Compound 4, half-maximal inhibitory concentration: > 50000 nM
Compound 4: only a limit was reported; the forecaster's own chance of this, stated with the estimate: 65%; the middle value lies on the limit itself.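

Compound 4 gives > 50000 nM in this assay, which is a limit of the assay and not a number. The change from benzyl(methyl)amino to (1-phenylethyl)amino on the carbonyl carbon, which brings an amide hydrogen and a defined stereocentre, therefore gives no measurable value, and the series gathers further at one point: the limit of > 50000 nM in this assay, at which 3 of the 4 values shown sit. Among the compounds shown here, the only readable comparison is an at least 1.2-fold higher number from compound 2 to compound 4 (0.08 log units; that floor lies within the scatter), while the steps to compound 4 from compound 3 and from compound 1 cannot be read.

Compound 2, at 41200 nM, remains the only compound with a measured number, and no step shown goes beyond the scatter. On these data alone, it stays open whether the opposite enantiomer of (1-phenylethyl)amino, or a piperazin-1-yl group or free carboxylic acid at this carbonyl carbon, would give a value clear of the limit.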